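A few compounds are considered here, and "the series" means these few. Any claim that something is new, unique, unknown or untested is made for them only; others in the source may bear on it.

Measured compounds:
- compound 1, `CCCCc1nc(=O)c(S(=O)(=O)c2ccc(-c3cccnc3)cc2)c(O)n1-c1c(OC)cccc1OC`: 88% in an ADME assay on microsomes from liver (Homo sapiens) for metabolic stability, using NADPH, with a stated time of 10 min; on this read-out lower numbers stand for a less stable compound and higher numbers for a more stable compound
- compound 2, `CCCCc1[nH]c(=O)c(S(=O)(=O)c2ccc(-c3ccc(F)cc3)cc2)c(O)c1-c1c(OC)cccc1OC`: "not determined" (no result reported) in this assay

Going by the values given here, compound 1 is the only compound here with a number. In this assay compound 1 gives 88%, a high fraction remaining, which places it at the stable end of the read-out. Among the compounds with values here, compound 2 carries no result, so there is no pair of measured compounds from which a step of this kind could be read, and nothing can be said about how the compounds compare with each other.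

The step to compound 3, `CCCCc1nc(=O)c(S(=O)(=O)c2ccccc2)c(O)n1-c1c(OC)cccc1OC`, changes compound 1 in one place: hydrogen in place of pyridin-3-yl on an aromatic carbon. Within the data shown here, with no measured step in hand, the expectation rests on the single value of compound 1 alone. Compound 3 is expected to stay close to compound 1, with a step of a number 8 percentage points lower from compound 1 to compound 3 (within the scatter) that is expected to lie within or only just beyond the usual scatter, and if anything tending slightly downward. The estimate for compound 3 in this assay is therefore 80%, with a plausible range from 55% to 95%.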

Compound 3, percent of the compound remaining: 89%
Estimate against measurement, compound 3: 9 percentage points below, and the stated range covers the measured number.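

In this assay, going by these compounds alone, the step of a number 1 percentage points higher from compound 1 to compound 3 (within the scatter) gives the first measured reading at this position, on an aromatic carbon of a six-membered aromatic ring of carbon only, para to a large group. It shows that, on this read-out, a compound with hydrogen at this position cannot be told apart from one with pyridin-3-yl, so the whole six-membered aromatic ring with its hetero atom can go without a difference beyond the scatter, and both compounds stay at the stable end. Nothing shown here gives a reason for this result.

As far as these compounds go, only pyridin-3-yl and hydrogen have numbers at this position, so it remains open whether an amine, a carboxylic acid or a plain phenyl placed there would also stay within the scatter of compound 1. From the compounds shown here alone, since this single step concerns one position on the shared core, it also remains open whether the same holds once a longer chain or another group is placed elsewhere on the core.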